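Anilide variation on the shared core: compound 3

A few compounds are considered here, and "the series" means these few. Any claim that something is new, unique, unknown or untested is made for them only; others in the source may bear on it.

Among the measured compounds shown here, in a functional assay on PC-3 cells (Homo sapiens) for inhibition, read by MTT assay, with a stated time of 72 h (a lower number here means a stronger inhibitor, a higher number a weaker inhibitor), compound 2 `O=C(CSc1nc(Nc2ccccc2)c2ccccc2n1)Nc1ccc([N+](=O)[O-])cc1` gives 25000 nM; the only other number measured comes from compound 1 `O=C(CSc1nc(Nc2ccccc2)c2ccccc2n1)Nc1ccccc1Br`, which gives 19800 nM in this assay, and the step of a 1.3-fold higher number from compound 1 to compound 2 (0.10 log units; within the scatter) lies within the scatter. Compound 3 `O=C(CSc1nc(Nc2ccccc2)c2ccccc2n1)Nc1ccc(F)c(Cl)c1` differs from compound 2 by 3-chloro-4-fluorophenyl in place of 4-nitrophenyl on an amide-type nitrogen. For the measured compounds named here, the single measured step at this place, a 1.3-fold higher number from compound 1 to compound 2 (0.10 log units; within the scatter), was within the scatter, so for compound 3 no change beyond the scatter is expected in this assay, a 1.3-fold lower number from compound 2 to compound 3 (0.10 log units; within the scatter). Compound 3 is therefore estimated at 20000 nM, with a range from 7000 nM to 60000 nM.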

Compound 3, half-maximal inhibitory concentration: 15500 nM
Compound 3: the middle estimate sits 1.3-fold (0.11 log units) above what was measured; low and high end bracket the measured number.
By their numbers in this assay, from the lowest: compounds 3, 1 and 2 (each within the scatter of the next).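

In this assay the 3-chloro-4-fluorophenyl group gives no separation from either earlier anilide: a 1.6-fold lower number from compound 2 to compound 3 (0.21 log units; within the scatter) and a 1.3-fold lower number from compound 1 to compound 3 (0.11 log units; within the scatter). Even the exchange of 4-nitrophenyl, with its hydrogen-bond acceptors, for a ring carrying only halogens stays within the scatter, so all three groups on the amide-type nitrogen read alike here.

Open, as far as these compounds go, is what an amine, a carboxylic acid or a longer chain would give in place of the aryl ring on that nitrogen, and what any change elsewhere on the shared core would give. No measured evidence bears on this result.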